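Hydroxyethyl for cyclopropyl on the shared core

A few compounds are considered here, and "the series" means these few. Any claim that something is new, unique, unknown or untested is made for them only; others in the source may bear on it.

Three compounds of this series have numbers in a functional assay on MCF7 cells (Homo sapiens) for inhibition, read by fluorescence, with a stated time of 72 h; a lower number here means a stronger inhibitor of growth, a higher number a weaker inhibitor of growth. Compound 1 `CC(C)c1nccc2nn(-c3ccccc3)cc12` gives 98800 nM. Compound 2 `Cc1nc(C2CC2)cc2nn(-c3ccccc3)cc12` gives 63500 nM. Compound 3 `CCCCCc1cc2nn(-c3ccccc3)cc2cn1` gives 11800 nM. Among these three, compound 2 holds the second highest number; its nearest neighbour is compound 1, whose number lies within the scatter of that of compound 2, so no order between compound 1 and compound 2 can be read. Compound 3 is the furthest from compound 2, with a number beyond the scatter in the lower direction.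

Compound 4 `Cc1nc(CCO)cc2nn(-c3ccccc3)cc12` has not yet been measured in this assay. Compared with compound 2 the change is 2-hydroxyethyl in place of cyclopropyl on an aromatic carbon. Among the measured compounds shown here, no pair of measured compounds shows this change, so no measured step can be quoted for it. The three measured compounds vary only in the group at this position and in the methyl, and they span a range of modest width.

The expectation is a step within or just beyond the scatter, with the number more likely to rise than to fall, so that from compound 2 to compound 4 the change is estimated as a 1.3-fold higher number from compound 2 to compound 4 (0.13 log units; within the scatter). Compound 4 is therefore expected to give about 85000 nM, with a range from 25000 nM to 250000 nM.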

Compound 4, concentration for 50% growth inhibition: > 100000 nM
Compound 4 gave a limit, no number; the forecaster's own chance of this, stated with the estimate: 30%; middle value at least 1.1-fold (0.07 log units) from the limit.
By their numbers in this assay, from the lowest: compound 3; then compounds 2 and 1 (each within the scatter of the next). At a limit, above all of these: compound 4.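

In this assay compound 4 stands at a limit of the assay, > 100000 nM, and this is not a number. The earlier compounds shown here offered no pair differing in one place, whereas this result gives a single change at this aromatic carbon, with the methyl kept: 2-hydroxyethyl in place of cyclopropyl gives an at least 1.5-fold higher number from compound 2 to compound 4 (0.19 log units; that floor lies within the scatter). No gain in growth inhibition comes with this open chain carrying a hydrogen-bond donor and acceptor, but the step has only a floor and no measured size, and no shift beyond the scatter can be claimed from that floor: the limit of > 100000 nM in this assay, at which 1 of the 4 values shown sits.

Compound 2 gives 63500 nM. Open, as far as these compounds go, is whether an amine, a carboxylic acid or a longer alkyl chain at this carbon, with the methyl kept, would move the number beyond the scatter of compound 2 in either direction. Compound 3 has a lower number but differs from compound 2 in more than one place, so it cannot settle what a longer chain does here.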